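This account rests on a few compounds, and the source may have more. Where it says the series, first, only, none or still open, it means among the compounds named here.

Compound 1 `C[C@@H]1CC[C@@H]2[C@@H](C1)O[C@@H](c1ccccc1)CC2(C)O` is measured in an ADME assay on MDCK cells (Canis lupus familiaris) for cytotoxicity, read by MTT assay, with a stated time of 48 h (a lower number here means that less compound is tolerated, a higher number that more compound is tolerated), at 580000 nM, the highest of the two numbers shown. Compound 2 `C[C@@H]1CC[C@@H]2[C@@H](C1)O[C@@H](c1ccc(O)cc1)CC2(C)O` gives 127000 nM. For compound 3 `C[C@@H]1CC[C@@H]2[C@@H](C1)O[C@@H](c1ccc([N+](=O)[O-])cc1)CC2(C)O` this assay reports only a limit, > 982000 nM; that is the limit of > 982000 nM in this assay, at which 1 of the 3 values shown sits. Compound 4 `C[C@@H]1CC[C@@H]2[C@@H](C1)O[C@@H](c1ccccc1)CC2(C)F` differs from compound 1 by fluoro in place of hydroxy on a saturated ring carbon. The measured steps all sit on the aromatic ring: a 4.6-fold lower number from compound 1 to compound 2 (0.66 log units; beyond the scatter), an at least 1.6-fold higher number from compound 1 to compound 3 (0.22 log units; that floor lies within the scatter) and an at least 7.7-fold higher number from compound 2 to compound 3 (0.88 log units; beyond the scatter). None of them touches the saturated ring carbon that changes here, so they give no direct guide, and no step beyond the scatter is expected in this assay. Compound 4 is therefore estimated at 500000 nM, within 150000 nM to 1500000 nM, which is expected to mean a 1.2-fold lower number from compound 1 to compound 4 (0.06 log units; within the scatter).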

Compound 4, half-maximal cytotoxic concentration: 65000 nM
Compound 4: middle estimate off by 7.7-fold (0.89 log units), on the high side, and the stated range ends above it.
By their numbers in this assay, from the lowest: compounds 4 and 2 (each within the scatter of the next); then compound 1. At a limit, above all of these: compound 3.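

Within the data shown here, the saturated ring carbon, which no earlier step touched, proves not to be a silent position in this assay: fluoro in place of hydroxy gives an 8.9-fold lower number from compound 1 to compound 4 (0.95 log units; beyond the scatter). The hydrogen-bond donor and acceptor of the hydroxy leave with it, and fluoro brings neither. Nothing available gives a cause for this step.

As far as these compounds go, whether the step follows from losing hydroxy or from bringing in fluoro stays open; an amine or a methoxy group on this carbon would help separate the two. From the compounds shown here alone, how fluoro here combines with hydroxy or nitro on the aromatic ring also remains open.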